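The compounds below may be only part of what the source reports. "The series", "measured", "known", "first", "only" and "open" are said of these compounds alone.

The series shares the core of compound 1 `Cc1nn(-c2nc(-c3ccc(Cl)c(Cl)c3)c(SC(C)C)s2)c(C(=O)O)c1-c1ccccc1` and varies only the aryl group attached to it. In a functional assay on BJAB cells (Homo sapiens) for antiproliferative activity, with a stated time of 4 days (a higher number here means that more compound is needed for the effect, a lower number that less compound is needed), compound 1 gives 3000 nM, the lowest of the three numbers shown, although all three lie within the scatter of one another. Compound 2 `Cc1nn(-c2nc(-c3ccc(Cl)c(Cl)c3)c(SC(C)C)s2)c(C(=O)O)c1-c1cc(C#N)cc(C(F)(F)F)c1` gives 3600 nM in this assay, and compound 3 `Cc1nn(-c2nc(-c3ccc(Cl)c(Cl)c3)c(SC(C)C)s2)c(C(=O)O)c1-c1ccncc1` gives 5900 nM. The steps are a 1.2-fold higher number from compound 1 to compound 2 (0.08 log units; within the scatter), a 2.0-fold higher number from compound 1 to compound 3 (0.29 log units; within the scatter) and a 1.6-fold higher number from compound 2 to compound 3 (0.21 log units; within the scatter): none of the changes made to this ring so far has moved the number beyond the scatter.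

Compound 4 `Cc1nn(-c2nc(-c3ccc(Cl)c(Cl)c3)c(SC(C)C)s2)c(C(=O)O)c1-c1cccc(C(F)(F)F)c1` is not yet measured. From compound 1 the change is trifluoromethyl in place of hydrogen on an aromatic carbon. The step from compound 1 to compound 2 bears most directly on it, since that change also brought a trifluoromethyl onto this ring together with a nitrile, and it stayed within the scatter; the step from compound 1 to compound 3 was likewise within the scatter. With no measured change at this ring having moved the number beyond the scatter, compound 4 is expected to remain close to compound 1. For compound 4 the expected step is a 1.1-fold higher number from compound 1 to compound 4 (0.04 log units; within the scatter), not beyond the scatter. The estimate for compound 4 in this assay is 3300 nM, with a range from 1500 nM to 7000 nM.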

Compound 4, half-maximal effective concentration: 22000 nM
Compound 4: middle estimate off by 6.7-fold (0.82 log units), on the low side; the measured number lies above the stated range.
By their numbers in this assay, from the lowest: compounds 1, 2 and 3 (each within the scatter of the next); then compound 4.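

In this assay this ring is not as tolerant as compounds 1, 2 and 3 suggested: trifluoromethyl in place of hydrogen, on an aromatic carbon meta to a large group, gives a 7.3-fold higher number from compound 1 to compound 4 (0.87 log units; beyond the scatter) and also sets compound 4 apart from the pyridin-4-yl compound, with a 3.7-fold higher number from compound 3 to compound 4 (0.57 log units; beyond the scatter) as the step. Trifluoromethyl on this ring does not by itself carry the change, since compound 2 has the group together with a nitrile and stays within the scatter of compound 1, while removing that nitrile gives a 6.1-fold higher number from compound 2 to compound 4 (0.79 log units; beyond the scatter) as the step, so the outcome at this position depends on what else the ring carries. No measurement among the data shown accounts for this difference.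

The compounds shown leave open whether the step is specific to trifluoromethyl or would also appear with a chlorine, a methyl or a methoxy group in the same place. They also leave open how a nitrile alone on this ring would compare with compound 1 and compound 4.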